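A few compounds are considered here, and "the series" means these few. Any claim that something is new, unique, unknown or untested is made for them only; others in the source may bear on it.

Measured compounds:
- compound 1 `CCCCCCc1ccc(C(=O)/C=C\C(=O)O)cc1`: 19200 nM
- compound 2 `CCCCCCc1ccc(C(=O)CCBr)cc1`: 4200 nM

In an assay on isolated protein for displacement of a labelled ligand from thyroid hormone receptor alpha (Homo sapiens), read by fluorescence polarization (on this read-out higher numbers stand for weaker inhibition and lower numbers for stronger inhibition), compound 2 stands at the lowest of the two numbers shown; the one measured step, a 4.6-fold lower number from compound 1 to compound 2 (0.66 log units; beyond the scatter), separates it from compound 1. Compound 3 `CCCCCCc1ccc(C(=O)C2CO2)cc1` differs from compound 2 by oxiran-2-yl in place of 2-bromoethyl on a carbonyl carbon. Within the data shown here, no measured step replaces a 2-bromoethyl with an oxiran-2-yl; the only step, a 4.6-fold lower number from compound 1 to compound 2 (0.66 log units; beyond the scatter), concerns a different group, so it bears on this change only loosely. No step beyond the scatter is therefore expected, and the estimated step is a 1.2-fold higher number from compound 2 to compound 3 (0.08 log units; within the scatter). Compound 3 is expected to give 5000 nM in this assay, within 1500 nM to 16000 nM.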

Compound 3, half-maximal inhibitory concentration in the thyroid hormone receptor alpha assay: 33200 nM
Compound 3: middle estimate off by 6.6-fold (0.82 log units), on the low side, and the stated range ends below it.
By their numbers in the thyroid hormone receptor alpha assay, from the lowest: compound 2; then compounds 1 and 3 (each within the scatter of the next).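

In the thyroid hormone receptor alpha assay, the group on this carbonyl carbon matters: oxiran-2-yl in place of 2-bromoethyl gives a 7.9-fold higher number from compound 2 to compound 3 (0.90 log units; beyond the scatter), so compound 3 does not keep the lower number of compound 2. Oxiran-2-yl in place of 2-carboxyethenyl gives a 1.7-fold higher number from compound 1 to compound 3 (0.24 log units; within the scatter), which leaves only the 2-bromoethyl group apart from the other two. In a physicochemical assay for solubility, in phosphate buffer (a lower number here means a less soluble compound, a higher number a more soluble compound), compound 2 gives 85000 nM and compound 3 gives 204000 nM. In the physicochemical assay, the same change moves solubility upward: the measured solubility of compound 2, 85000 nM, and of compound 3, 204000 nM, a 2.4-fold higher number (0.38 log units; beyond the scatter)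

Whether the bromine atom or the open chain accounts for the number of compound 2 stays open; a 2-chloroethyl or a propyl group on the same carbonyl carbon would separate the two.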